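Benzyl extension at the ring nitrogen: outlook for compound 3

A few compounds are considered here, and "the series" means these few. Any claim that something is new, unique, unknown or untested is made for them only; others in the source may bear on it.

Working notes on the series. Compound 1 `Cn1nc(-c2ccccc2)c2cc(C(=N)Nc3ccccc3)ncc21` is one of two compounds with a number in a functional assay on HT-1080 cells (Homo sapiens) for cytotoxicity, read by MTT assay, with a stated time of 72 h; a lower number here means a stronger inhibitor, a higher number a weaker inhibitor. In this assay compound 1 gives 17400 nM, the higher of the two numbers. Compound 2 `COc1cc(Nc2nc(C(=N)Nc3ccccc3)cc3c(-c4ccccc4)n[nH]c23)cc(OC)c1OC` differs from compound 1 in more than one place. In this assay compound 2 gives 3900 nM. The two values show compound 2 at the lower number, and the gap between them lies beyond the scatter. Among the compounds with values here, no step between measured compounds that differ in only one place is available.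

Compound 3 `COc1ccc(Cn2nc(-c3ccccc3)c3cc(C(=N)Nc4ccccc4)ncc32)cc1` is not yet measured. It differs from compound 1 by 4-methoxyphenyl in place of hydrogen on a saturated chain carbon bound to an aromatic nitrogen; the same difference cut one bond further out reads methyl to 4-methoxybenzyl. Within the data shown here, nothing among the measured compounds isolates this change, since compound 2 carries a hydrogen at that aromatic nitrogen and differs elsewhere as well. The step expected here, a 1.9-fold lower number from compound 1 to compound 3 (0.29 log units; within the scatter), is modest and towards a lower number, and may not reach beyond the scatter. Compound 3 is expected to give 9000 nM in this assay, within 2500 nM to 30000 nM.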

Compound 3, half-maximal inhibitory concentration: 4700 nM
For compound 3 the middle estimate is 1.9-fold (0.28 log units) above the measured one; the measured number falls inside the stated range.
By their numbers in this assay, from the lowest: compounds 2 and 3 (each within the scatter of the next); then compound 1.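

Within the data shown here, the change of methyl to 4-methoxybenzyl gives the first comparison that differs in one place only, and in this assay it comes with a 3.7-fold lower number from compound 1 to compound 3 (0.57 log units; beyond the scatter) as its result. The position, a saturated chain carbon bound to an aromatic nitrogen, therefore accepts 4-methoxyphenyl in place of hydrogen without a rise in the number, and the group entering here, with its 8 heavy atoms, changes the read-out by more than the scatter. No measurement at hand gives a reason for this step.

Going by these compounds, it remains open whether the lower number follows the aromatic ring or the methoxy group, and whether plain benzyl, 4-chlorobenzyl or a longer chain such as phenethyl would give a number on the same side of compound 1. Also open, on these data alone, is whether an amine or a carboxylic acid carried on the same chain carbon would keep the lower number, and whether the step would hold on any core other than that of compound 1.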